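Compound 3: One Stereocentre Drawn the Other Way

The source may hold more compounds than are shown below. What is called first, only, known or untested is meant among the compounds shown, and "the series" means these compounds.

compound 1 `CO[C@@H]1O[C@H](COC(=O)c2nnn(Cc3ccccc3)c2C)[C@H]2OC(C)(C)O[C@@H]12` gives 837000 nM
compound 2 `Cc1c(C(=O)O[C@H]2[C@H]3OC(C)(C)O[C@H]3O[C@@H]2[C@H]2COC(C)(C)O2)nnn1Cc1ccccc1` gives 3530000 nM

In an ADME assay on Vero cells (Chlorocebus sabaeus) for cytotoxicity, read by MTT assay, with a stated time of 72 h (on this read-out higher numbers stand for lower toxicity in this test and lower numbers for higher toxicity in this test), compound 2 stands higher at 3530000 nM of the two, and compound 1 lies lower at 837000 nM with the gap beyond the scatter. Compound 3 `Cc1c(C(=O)O[C@@H]2[C@H]3OC(C)(C)O[C@H]3O[C@@H]2[C@H]2COC(C)(C)O2)nnn1Cc1ccccc1` has not yet been measured. It departs from compound 2 in configuration alone (the two compounds have the same atoms and bonds and differ only in configuration as drawn: 1 of 5 stereo elements differ; a stereocentre at a saturated ring carbon is drawn R in compound 2 and S in compound 3), with nothing leaving and nothing entering. Among the measured compounds shown here, no two measured compounds differ in one place, so the data give no direct size for a change of this kind. The expectation therefore rests on compound 2 at 3530000 nM as the closest reference. The expected step of a 1.2-fold lower number from compound 2 to compound 3 (0.07 log units; within the scatter) is estimated to stay within the scatter, with no direction favoured. The estimate for compound 3 is 3000000 nM (expected range 1100000 nM to 8000000 nM).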

Compound 3, half-maximal cytotoxic concentration: 208000 nM
Beside the measured number, compound 3's estimate is 14-fold (1.16 log units) above it; the measured number lies below the stated range.
By their numbers in this assay, from the lowest: compound 3; then compound 1; then compound 2.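

In this assay the configuration at this saturated ring carbon proves to matter: redrawing the stereocentre from R to S gives a 17-fold lower number from compound 2 to compound 3 (1.23 log units; beyond the scatter), so the lower number here stands for higher toxicity in this test. Among the compounds shown here, compound 1 and compound 2 differ in more than one place and could give no such reading, so this is the first size for any single change. The step can be assigned to this one stereocentre because nothing leaves and nothing enters: the fact that compounds 2 and 3 differ only in the configuration as drawn.

The compounds shown leave open whether the same inversion would give a step of this size if an amide replaced the ester link or if an amine were carried on the shared core. They also leave open how the remaining stereo elements would behave if redrawn one at a time.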